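Dropping the Aryl Chloride from a Triazole-Bearing Core

The source may report more compounds than this note shows. Statements on the series, on what has been measured and on what is new or still open speak of the compounds shown alone.

Compound 3 `C=C1C(=O)[C@]23C[C@@]1(O)CC[C@H]2c1ccc(O)c(C)c1[C@@H]3Cn1cc(-c2ccc(Cl)cc2)nn1` carries a 4-chlorophenyl group on its triazole and a carbonyl on the shared core. In a functional assay on HL-60 cells (Homo sapiens) for cytotoxicity, read by MTT assay, with a stated time of 4 days (on this read-out higher numbers stand for weaker inhibition and lower numbers for stronger inhibition), compound 3 gives 690 nM, the lowest of the two numbers recorded. Compound 1 `C=C1C[C@]23C[C@@]1(O)CC[C@H]2c1ccc(O)c(C)c1[C@@H]3Cn1cc(-c2ccc(C(F)(F)F)cc2)nn1`, which lacks the carbonyl and bears a trifluoromethyl on its aryl group, gives 8950 nM in this assay. Compound 2 `C=C1C[C@]23C[C@@]1(O)CC[C@H]2c1ccc(OS(=O)(=O)c2ccc(C)cc2)c(C)c1[C@@H]3Cn1cc(-c2ccc(C(F)(F)F)cc2)nn1` reaches only a limit in this assay, > 20000 nM (the limit of > 20000 nM in this assay, at which 1 of the 3 values shown sits). Among the measured compounds shown here, the single measured step, an at least 2.2-fold higher number from compound 1 to compound 2 (0.34 log units; beyond the scatter), concerns the (4-methylphenyl)sulfonyl on the oxygen of the aromatic ring and says nothing about the aryl group on the triazole.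

Compound 4 `C=C1C(=O)[C@]23C[C@@]1(O)CC[C@H]2c1ccc(O)c(C)c1[C@@H]3Cn1cc(-c2ccccc2)nn1` differs from compound 3 by hydrogen in place of chloro on an aromatic carbon, read one bond further out as 4-chlorophenyl to phenyl. For the measured compounds named here, no measured step addresses this change. Compound 1 and compound 3 differ at two places at once, so their two values cannot be split between the carbonyl and the aryl substituent. The author therefore expects a step from compound 3 to compound 4 of a 1.7-fold higher number from compound 3 to compound 4 (0.24 log units; within the scatter), within the scatter or at most modest, toward a higher number. Compound 4 is estimated at 1200 nM, with a range from 400 nM to 3600 nM.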

Compound 4, half-maximal inhibitory concentration: 750 nM
Beside the measured number, compound 4's estimate is 1.6-fold (0.20 log units) above it, within the range that was stated.
By their numbers in this assay, from the lowest: compounds 3 and 4 (each within the scatter of the next); then compound 1. At a limit, above all of these: compound 2.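

In this assay, hydrogen in place of chloro on the aromatic carbon gives a 1.1-fold higher number from compound 3 to compound 4 (0.04 log units; within the scatter) and so leaves the two compounds indistinguishable. Among the compounds shown here, this is the first reading of this position with the rest of the structure held fixed, since the only earlier step concerned the group on the oxygen of the aromatic ring. It shows that, on the core carrying the carbonyl, the chloro para to a large group is not needed for a number of this size, and that 4-chlorophenyl and phenyl cannot be told apart here, though no measurement shown gives a reason for this result.

With only chloro and hydrogen shown at this position, it remains open whether a methoxy, an amine or a carboxylic acid there would leave the number where it is, and how the trifluoromethyl would read on the core carrying the carbonyl. The share of the carbonyl itself also stays open, as no pair of compounds shown differs at that place alone.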